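Swapping furan for thiophene on a shared core

The source may report more compounds than this note shows. Statements on the series, on what has been measured and on what is new or still open speak of the compounds shown alone.

Compound 2: `CCOC(=O)c1cnn(-c2nc(-c3ccco3)c(C#N)c(=O)n2C)c1N` — 104 ug/mL
Compound 1: `CCOC(=O)c1cnn(-c2nc(-c3ccccc3O)c(C#N)c(=O)n2C)c1N` — 58 ug/mL

Compound 2 has the higher of the two numbers in a functional assay, with a stated time of 10 min (a lower number here means a stronger inhibitor, a higher number a weaker inhibitor), and compound 1 sits within the scatter of it, since a 1.8-fold higher number from compound 1 to compound 2 (0.25 log units; within the scatter). Compound 3, `CCOC(=O)c1cnn(-c2nc(-c3cccs3)c(C#N)c(=O)n2C)c1N`, differs from compound 2 only by thiophen-2-yl in place of furan-2-yl on an aromatic carbon. Going by the values given here, the one measured step, from compound 1 to compound 2, changed a different group and stayed within the scatter, so no step on this ring has yet moved this assay beyond the scatter. Compound 3 is therefore expected to give about 100 ug/mL in this assay, between 50 ug/mL and 200 ug/mL, a step of a 1.0-fold lower number from compound 2 to compound 3 (0.02 log units; within the scatter) from compound 2, which is no change beyond the scatter.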

Compound 3, half-maximal inhibitory concentration: 109 ug/mL
Beside the measured number, compound 3's estimate is 1.1-fold (0.04 log units) below it; the measured number falls inside the stated range.
By their numbers in this assay, from the lowest: compounds 1, 2 and 3 (each within the scatter of the next).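

In this assay, thiophen-2-yl in place of furan-2-yl gives a 1.0-fold higher number from compound 2 to compound 3 (0.02 log units; within the scatter) and so exchanges the ring oxygen for sulfur with no change beyond the scatter at this aromatic carbon. Set against 2-hydroxyphenyl, thiophen-2-yl gives a 1.9-fold higher number from compound 1 to compound 3 (0.27 log units; within the scatter), so the three aromatic groups at this place cannot be told apart in this assay. No supporting evidence is available to account for this result. Still open, from the compounds shown here alone, is whether an amine, a carboxylic acid or a longer chain at this place would move the number beyond the scatter.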